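The source may hold more compounds than are shown below. What is called first, only, known or untested is meant among the compounds shown, and "the series" means these compounds.

Measured compounds:
compound 1 `O=C(O)Cc1sc(C(c2ccccc2)c2ccc(Cl)cc2)nc1-c1ccc(Cl)cc1` – 45 nM
compound 2 `NS(=O)(=O)c1cccc(-c2nc(C(c3ccc(F)cc3)c3ccc(F)cc3)sc2CC(=O)O)c1` – 140 nM

In an in vitro assay on HEK385-7 cells for displacement of a labelled ligand from prostaglandin D2 receptor 2 (Homo sapiens) (a lower number here means a stronger inhibitor, a higher number a weaker inhibitor), compound 2 gives 140 nM, the higher of the two numbers; compound 1 gives 45 nM, a lower number by a gap beyond the scatter. Among the compounds with values here, no pair of measured compounds differs in one place, so no single change has a known step. Compound 3 `CN(C)c1cc(-c2nc(C(c3ccc(F)cc3)c3ccc(F)cc3)sc2CC(=O)O)ccn1` is derived from compound 2 by one change: 2-(dimethylamino)pyridin-4-yl in place of 3-sulfamoylphenyl on an aromatic carbon. Within the data shown here, no measured step bears on this change; the step of a 1.8-fold higher number from compound 2 to compound 3 (0.25 log units; within the scatter) is expected to be small, upward, and near the edge of the scatter. Compound 3 is expected to give 250 nM, within 60 nM to 1000 nM.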

Compound 3, half-maximal inhibitory concentration: 380 nM
Compound 3: middle estimate off by 1.5-fold (0.18 log units), on the low side; the range from low to high includes it.
By their numbers in this assay, from the lowest: compound 1; then compound 2; then compound 3.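

In this assay, putting 2-(dimethylamino)pyridin-4-yl in place of 3-sulfamoylphenyl on the aromatic carbon next to the ring nitrogen gives a 2.7-fold higher number from compound 2 to compound 3 (0.43 log units; beyond the scatter) and so shows that this position does not treat the two groups alike. The entering group has no hydrogen-bond donor and the same count of acceptors, but one step cannot tie the shift to that difference. Nothing at hand explains the shift.

Still open, on these data alone, is whether the step follows the loss of the sulfamoyl group, the dimethylamino group or the ring nitrogen of the entering group. An unsubstituted phenyl, or a pyridin-4-yl carrying a primary amine, would bear on that.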